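A few compounds are considered here, and "the series" means these few. Any claim that something is new, unique, unknown or untested is made for them only; others in the source may bear on it.

Of the compounds shown here, two built on a shared core have been tested in a functional assay on CFPAC-1 cells (Homo sapiens) for antiproliferative activity, read by MTT assay, with a stated time of 72 h; on this read-out lower numbers stand for stronger inhibition and higher numbers for weaker inhibition. Compound 1 `CC(C)(C)OC(=O)N1CCN(C(=S)SCc2cn(C[C@H](O)[C@H]3OC(=O)C(OCc4ccccc4)=C3OCc3ccccc3)nn2)CC1` gives in this assay only a limit, > 100000 nM, and not a number. Among the measured compounds shown here, compound 2 `CCCCCCCCCCc1cn(C[C@H](O)[C@H]2OC(=O)C(OCc3ccccc3)=C2OCc2ccccc2)nn1` gives in this assay 40300 nM, the only actual number among the values shown. Compound 3 `COc1ccc(-c2cn(C[C@H](O)[C@H]3OC(=O)C(OCc4ccccc4)=C3OCc3ccccc3)nn2)cc1` differs from compound 2 by 4-methoxyphenyl in place of decyl on an aromatic carbon. For the measured compounds named here, no measured pair of compounds differing in one place is available to gauge this change. A step within the usual scatter, in no clear direction, is expected: a 1.0-fold lower number from compound 2 to compound 3 (0.00 log units; within the scatter). Compound 3 is estimated at 40000 nM, between 10000 nM and 150000 nM.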

Compound 3, half-maximal inhibitory concentration: 26000 nM
Compound 3: the middle estimate sits 1.5-fold (0.19 log units) above what was measured; low and high end bracket the measured number.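

On this aromatic carbon of the five-membered ring, 4-methoxyphenyl in place of decyl gives a 1.6-fold lower number from compound 2 to compound 3 (0.19 log units; within the scatter) and so a group with an aromatic ring and a straight chain read alike here. The swap of chain for ring thus moves the result no further than repeat measurements would. Both numbers stay in the weak part of this read-out, with its ceiling not far off: (the limit of > 100000 nM in this assay, at which 1 of the 3 values shown sits). On these data alone, whether an amine or a carboxylic acid on this carbon would give a clearly lower number stays open. So does the outcome of a hydroxyl in place of the methoxy on the six-membered ring.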